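The source may hold more compounds than are shown below. What is called first, only, known or untested is meant among the compounds shown, and "the series" means these compounds.

In an ADME assay on microsomes from liver (Homo sapiens) for metabolic stability, read by LC-MS, with a stated time of 10 min, tested at 0.5 uM (a lower number here means that less of the compound is left, a higher number that more of the compound is left), compound 3 `c1cnc2c(c1)CCC[C@@H]2N(CCCN1CCNCC1)Cc1cc2ccccc2cn1` gives 66% as the lowest of three numbers. Compound 1 `c1ccc2c(c1)CN[C@H](CN(CCCN1CCNCC1)[C@H]1CCCc3cccnc31)C2` gives 99% and compound 2 `c1ccc2c(c1)CN[C@@H](CN(CCCN1CCNCC1)[C@H]1CCCc3cccnc31)C2` gives 100% with a number 1 percentage points higher from compound 1 to compound 2 (within the scatter) as the step between them. Within the data shown here, compound 4 `c1cnc2c(c1)CN[C@H](CN(CCCN1CCNCC1)[C@H]1CCCc3cccnc31)C2` departs from compound 3 through a group of 10 heavy atoms (8 carbon, 2 nitrogen; one six-membered non-aromatic ring with 1 hetero atom, one six-membered aromatic ring with 1 hetero atom) in place of a group of 10 heavy atoms (9 carbon, 1 nitrogen; one six-membered aromatic ring of carbon only, one six-membered aromatic ring with 1 hetero atom), on a saturated chain carbon bound to an amine nitrogen as its single change. Two large measured steps bear on this: a number 33 percentage points lower from compound 1 to compound 3 (beyond the scatter) and a number 34 percentage points lower from compound 2 to compound 3 (beyond the scatter) with isoquinolin-3-yl entering in place of 1,2,3,4-tetrahydroisoquinolin-3-yl. Compound 4 again carries a six-membered non-aromatic ring, so a large rise of similar size is expected in this assay on the strength of those steps. The expected change is a number 27 percentage points higher from compound 3 to compound 4 (beyond the scatter) by this reckoning. Compound 4 is estimated at 93% with a range from 80% to 100%.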

Compound 4, percent of the compound remaining: 100%
For compound 4 the middle estimate is 7 percentage points below the measured one, and the stated range covers the measured number.
By their numbers in this assay, from the lowest: compound 3; then compounds 1, 2 and 4 (each within the scatter of the next).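

In this assay, the change gives a number 34 percentage points higher from compound 3 to compound 4 (beyond the scatter), so the rise seen earlier with 1,2,3,4-tetrahydroisoquinolin-3-yl also appears with a group whose aromatic ring holds a hetero atom and which keeps a six-membered non-aromatic ring. Placing that hetero atom in the aromatic ring leaves the number unmoved beyond the scatter, with no change at the digits printed from compound 2 to compound 4 (within the scatter) and a number 1 percentage points higher from compound 1 to compound 4 (within the scatter).

Whether a methoxy group on that aromatic ring, or a longer chain on the amine nitrogen, would keep such a number stays open, and nothing shown here explains these steps.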